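Alkyne substituent change at the cytotoxicity limit

The source may hold more compounds than are shown below. What is called first, only, known or untested is meant among the compounds shown, and "the series" means these compounds.

In an ADME assay on HepG2 cells (Homo sapiens) for cytotoxicity, read by MTT assay, with a stated time of 72 h (a lower number here means that less compound is tolerated, a higher number that more compound is tolerated), compound 1 `O=[N+]([O-])c1c(CS(=O)(=O)c2ccccc2)nc2c(C#Cc3ccccc3)cc(Cl)cn12` gives > 3900 nM as a limit. Compound 2 `O=[N+]([O-])c1c(CS(=O)(=O)c2ccccc2)nc2c(C#Cc3cccs3)cc(Cl)cn12` gives > 3900 nM as a limit, so it has no number. Within the data shown here, both values stand at the same limit (the limit of > 3900 nM in this assay, at which 2 of the 2 values shown sit), and the only measured step that the two limits leave unreadable from compound 1 to compound 2 has no readable size. Compound 3 `CC(O)(C#Cc1cc(Cl)cn2c([N+](=O)[O-])c(CS(=O)(=O)c3ccccc3)nc12)c1ccccc1` differs from compound 2 by 1-hydroxy-1-phenylethyl in place of thiophen-2-yl on a triple-bonded carbon with 1-hydroxy-1-phenylethyl in place of thiophen-2-yl on a triple-bonded carbon. No measured size carries over, so no step beyond the scatter is expected in this assay and no direction is favoured. The expected step is a step that the limit leaves unreadable from compound 2 to compound 3 as an estimate. Compound 3 is expected at 6000 nM (estimated range 3000 nM to 20000 nM).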

Compound 3, half-maximal cytotoxic concentration: 18800 nM
Compound 3: middle estimate off by 3.1-fold (0.50 log units), on the low side, within the range that was stated.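

No step can be read from compound 2 to compound 3 or from compound 1 to compound 3, since compound 1 and compound 2 each give only a limit: the limit of > 3900 nM in this assay, at which 2 of the 3 values shown sit. Going by these compounds, what stays open is how far compound 1 and compound 2 actually lie from compound 3 in this assay.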